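The source may hold more compounds than are shown below. What is called first, only, known or untested is meant among the compounds shown, and "the series" means these compounds.

In an assay for inhibition of acyl-CoA:cholesterol acyltransferase (Oryctolagus cuniculus), using microsomes (a higher number here means a weaker inhibitor, a lower number a stronger inhibitor), compound 1 `CCCCCCCCC(C)(C)C(=O)Nc1c(C)cc(C)c2c1OC(C)(C)C2` gives 140 nM, compound 2 `Cc1cc(C)c(NC(=O)C(C)(C)CCCCCc2ccccc2)c2c1CC(C)(C)O2` gives 120 nM and compound 3 `Cc1cc(C)c(NC(=O)C(C)(C)CCCCCCc2ccccc2)c2c1CC(C)(C)O2` gives 81 nM. Compound 3 has the lowest number of the three, though its gaps to compound 2 and to compound 1 are both within the scatter. Compound 4 `Cc1cc(C)c(NC(=O)C(C)(C)CCCCOc2ccc(Cl)cc2)c2c1CC(C)(C)O2` differs from compound 3 in one place: 4-chlorophenoxy in place of phenethyl on a saturated chain carbon, five bonds along the chain from a carbonyl carbon. For the measured compounds named here, the steps that bear on this are a 1.7-fold lower number from compound 1 to compound 3 (0.24 log units; within the scatter) and a 1.5-fold lower number from compound 2 to compound 3 (0.17 log units; within the scatter), with a 1.2-fold lower number from compound 1 to compound 2 (0.07 log units; within the scatter) alongside; all three leave the number essentially where it was. None of them tests an oxygen or a chlorine at the far end of the chain. A step of a 1.1-fold higher number from compound 3 to compound 4 (0.05 log units; within the scatter) is therefore expected, within the scatter. Compound 4 is estimated at 90 nM, with a range from 35 nM to 250 nM.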

Compound 4, half-maximal inhibitory concentration: 330 nM
Beside the measured number, compound 4's estimate is 3.7-fold (0.56 log units) below it; measured number above the stated range.
By their numbers in this assay, from the lowest: compounds 3, 2 and 1 (each within the scatter of the next); then compound 4.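

In this assay the 4-chlorophenoxy group moves the number beyond the scatter, with a 4.1-fold higher number from compound 3 to compound 4 (0.61 log units; beyond the scatter) and a 2.8-fold higher number from compound 2 to compound 4 (0.44 log units; beyond the scatter) and also a 2.4-fold higher number from compound 1 to compound 4 (0.37 log units; beyond the scatter) as the three steps, all upward. Among compound 1, compound 2 and compound 3, the changes on this chain all stayed within the scatter, so this position does not accept every group of this size alike. Nothing available accounts for the rise.

On these data alone, the step brings in the oxygen and the chlorine together, so their separate shares remain open. An unsubstituted phenoxy group and a 4-chlorophenethyl group would separate them.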